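The source may hold more compounds than are shown below. What is called first, only, known or untested is meant among the compounds shown, and "the series" means these compounds.

Three compounds share one core and differ only in the group attached to the nitrogen on an aromatic ring. Compound 1 `O=C(Nc1cccc(/C=C/C(=O)c2nc3ccccc3[nH]2)c1)c1ccc(Br)cc1` gives 2230 nM in a functional assay on HCT-116 cells (Homo sapiens) for antiproliferative activity, read by MTT assay, with a stated time of 48 h; a lower number here means a stronger inhibitor, a higher number a weaker inhibitor. Compound 2 `Cc1cccc(C(=O)Nc2cccc(/C=C/C(=O)c3nc4ccccc4[nH]3)c2)c1` gives 1420 nM, and compound 3 `O=C(Nc1cccc(/C=C/C(=O)c2nc3ccccc3[nH]2)c1)c1cccc(C(F)(F)F)c1` gives 3360 nM. The step is a 1.6-fold lower number from compound 1 to compound 2 (0.20 log units; within the scatter), while a 1.5-fold higher number from compound 1 to compound 3 (0.18 log units; within the scatter) and a 2.4-fold higher number from compound 2 to compound 3 (0.37 log units; beyond the scatter). Compound 2 thus has the lowest of the three numbers, though its gap to compound 1 lies within the scatter, so no ranking between those two is claimed.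

Compound 4 `Cc1ccc(S(=O)(=O)Nc2cccc(/C=C/C(=O)c3nc4ccccc4[nH]3)c2)cc1` differs from compound 2 in one place: (4-methylphenyl)sulfonyl in place of (3-methylphenyl)carbonyl on a nitrogen on an aromatic ring. For the measured compounds named here, each measured step exchanges only the aromatic ring on the carbonyl carbon; none replaces the carbonyl link by a sulfonyl, so no measured step bears directly on this change, and the direction is open. No step beyond the scatter is expected, but with wide uncertainty. Compound 4 is therefore estimated at 2000 nM, with a range from 500 nM to 8000 nM. The expected step is a 1.4-fold higher number from compound 2 to compound 4 (0.15 log units; within the scatter).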

Compound 4, half-maximal inhibitory concentration: 1990 nM
Compound 4: the middle estimate sits 1.0-fold (0.00 log units) above what was measured; the measured number falls inside the stated range.
By their numbers in this assay, from the lowest: compounds 2, 4, 1 and 3 (each within the scatter of the next, the first and the last beyond it).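

In this assay, a sulfonyl link on the nitrogen gives a number within the scatter of two carbonyl-linked compounds (a 1.4-fold higher number from compound 2 to compound 4 (0.15 log units; within the scatter); a 1.1-fold lower number from compound 1 to compound 4 (0.05 log units; within the scatter)). The earlier steps shown here exchanged only the aromatic ring on the carbonyl carbon, whereas this one shows that the carbonyl link itself can be replaced by a sulfonyl with no step beyond the scatter. No measurement of any property of these groups accompanies the result, so it stands without an explanation.

This exchange also puts 4-methylphenyl in place of 3-methylphenyl, so the compounds shown do not separate the effect of the link from that of the ring. Also open, on these data alone, is what number would follow on the sulfonyl from a butyl chain in place of the aromatic ring, or from an amine or a carboxylic acid in place of the methyl.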